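Benzoyl on the amine nitrogen of compound 1

The compounds below may be only part of what the source reports. "The series", "measured", "known", "first", "only" and "open" are said of these compounds alone.

Measured so far in a functional assay on MCF7 cells (Homo sapiens) for cytotoxicity, read by MTT assay, with a stated time of 72 h; on this read-out lower numbers stand for stronger inhibition and higher numbers for weaker inhibition:
- compound 1 `NCCCNc1c(C(=O)NCc2ccc(F)cc2)nc(Br)c2cccnc12` gives 6000 nM 
- compound 2 `N[C@H]1CC[C@H](Nc2c(C(=O)NCc3ccc(F)cc3)nc(Br)c3cccnc23)CC1` gives 2000 nM 

Compound 1 holds the higher of the two numbers in this assay and compound 2 is its nearest neighbour. Compound 3 `O=C(NCCCNc1c(C(=O)NCc2ccc(F)cc2)nc(Br)c2cccnc12)c1ccccc1` keeps the core of compound 1 and differs by benzoyl in place of hydrogen on an amine nitrogen. Among the compounds with values here, only one measured step bears on this, and only loosely: a 3.0-fold lower number from compound 1 to compound 2 (0.48 log units; beyond the scatter) is also a change in the 3-aminopropyl group, with 4-aminocyclohexyl in its place on a nitrogen on an aromatic ring. Within the data shown here, no measured compound carries benzoyl, so the direction remains open. A step of similar, modest size is expected in this assay with a slight lean toward lower numbers. The estimated step is a 2.4-fold lower number from compound 1 to compound 3 (0.38 log units; beyond the scatter) with wide margins. For compound 3 the estimated value is 2500 nM with an expected range from 700 nM to 9000 nM in this read-out.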

Compound 3, half-maximal inhibitory concentration: 2000 nM
Beside the measured number, compound 3's estimate is 1.3-fold (0.10 log units) above it; low and high end bracket the measured number.
By their numbers in this assay, from the lowest: compounds 2 and 3 (each within the scatter of the next); then compound 1.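

In this assay the amine nitrogen at the end of the 3-aminopropyl chain accepts benzoyl in place of hydrogen, and the change gives a 3.0-fold lower number from compound 1 to compound 3 (0.48 log units; beyond the scatter), so substitution at this position is tolerated and the number moves down modestly. Of the three compounds, only compound 3 lacks a free amino group on its side chain, so such a group is not required for cytotoxicity at this level in this assay within this small set. Nothing at hand explains why the number falls with this change.

On these data alone, it remains open whether the benzene ring or the carbonyl of the benzamido group carries the step, which acetyl or benzyl on the same nitrogen could help to separate. Also open, as far as these compounds go, is how benzoyl behaves on the amino group of the 4-aminocyclohexyl compound 2.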